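A Nitro Group Enters the Furan of Compound 3

This account rests on a few compounds, and the source may have more. Where it says the series, first, only, none or still open, it means among the compounds named here.

Three compounds were measured in a functional assay on the whole organism (strain Wistar Albino) for inhibition, with Rattus norvegicus as the target, read by paw edema, with a stated time of 2 h, at a dose of 20 mg/kg; a higher number here means more inhibition at the dose given (going by the name of the read-out), a lower number less inhibition. Compound 3 `COc1ccc(Cc2nnc3n2NC(c2ccco2)S3)cc1OC` gives 17.5% in this assay, the second highest of the three numbers. Its nearest neighbour is compound 2 `COc1ccc(Cl)c(-c2nnc3n2NC(c2ccco2)S3)c1`, which gives 18.7%, and the furthest is compound 1 `COc1ccc2[nH]c(C)c(Cc3nn4c(Cc5ccc(OC)c(OC)c5)nnc4s3)c2c1`, which gives 16.2%; both gaps to compound 3 lie within the scatter, so the three numbers cannot be told apart. For the measured compounds named here, no step between measured compounds that differ in a single place is available. Compound 4 `COc1ccc(Cc2nnc3n2NC(c2ccc([N+](=O)[O-])o2)S3)cc1OC` differs from compound 3 in one place: nitro in place of hydrogen on an aromatic carbon. Given the narrow spread of the three numbers, no step beyond the scatter is expected in this assay in either direction. Compound 4 is estimated at 20%, between 10% and 31%. The expected step is a number 2.5 percentage points higher from compound 3 to compound 4 (within the scatter).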

Compound 4, a percentage reported as inhibition, in the whole organism at one dose (the size of the read-out at that dose, not a potency): 17.6%
The estimate for compound 4 lay 2.4 percentage points above the measured number; the measured number falls inside the stated range.
By their numbers in this assay, from the lowest: compounds 1, 3, 4 and 2 (each within the scatter of the next).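

In this assay, for the compounds shown here, the change from furan-2-yl to 5-nitrofuran-2-yl gives a number 0.1 percentage points higher from compound 3 to compound 4 (within the scatter) and so provides the first comparison between compounds that differ in one place. At this aromatic carbon, nitro in place of hydrogen adds 3 heavy atoms, yet the two numbers cannot be told apart at this dose. Nothing measured here bears on the reason for this. From the compounds shown here alone, whether an amine or a carboxylic acid at the same carbon would also stay within the scatter remains open.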